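Working notes: replacing tert-butyl in compound 2

The compounds below may be only part of what the source reports. "The series", "measured", "known", "first", "only" and "open" are said of these compounds alone.

Compound 1 `O=C(O)CC(NC(=O)c1c(Cl)cccc1Cl)c1ccccc1`: > 100000 nM
Compound 2 `CC(C)(C)c1ccc(S(=O)(=O)NC(CC(=O)O)c2ccccc2)cc1`: > 100000 nM

Both entries come from a functional assay on MDA-MB-436 cells (Homo sapiens) for antiproliferative activity, read by MTT assay, with a stated time of 24 h (a lower number here means a stronger inhibitor, a higher number a weaker inhibitor), and each is a limit of the assay and not a number. For the measured compounds named here, the series so far stands at the limit of > 100000 nM in this assay, at which 2 of the 2 values shown sit. In this assay compound 2 gives > 100000 nM, which is only a limit.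

Compound 3 `O=C(O)CC(NS(=O)(=O)c1ccc(OC(F)(F)F)cc1)c1ccccc1` has trifluoromethoxy in place of tert-butyl on an aromatic carbon, para to a large group (trifluoromethoxy in place of tert-butyl on an aromatic carbon). Going by the values given here, the series holds no step between measured compounds, so the size of this change cannot be read from the data. No shift beyond the usual scatter is expected, and another limit is the likeliest outcome. The expected change is a number no higher from compound 2 to compound 3 (the limit leaves the size open). For compound 3 the estimated value is 100000 nM, with an expected range of 40000 nM to 250000 nM.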

Compound 3, half-maximal inhibitory concentration: > 100000 nM
Compound 3 was reported as a limit (the forecaster's own chance of this, stated with the estimate: 75%); the middle value sits exactly at the limit.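

Compound 2 and compound 3 are both limits of the assay and not numbers, so no step between them can be read: the limit of > 100000 nM in this assay, at which 3 of the 3 values shown sit.

The compounds shown leave open whether any replacement of tert-butyl on the shared core can give a measurable value.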